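The compounds below may be only part of what the source reports. "The series", "measured", "known", "first", "only" and "open" are said of these compounds alone.

Notes on the series. Compound 2 `CCC1C(=O)N(C)c2cnc(-n3ccc4cc(F)ccc43)nc2N1c1ccn(C)n1` and compound 1 `CCC1C(=O)N(C)c2cnc(-n3ccc4cc(C(=O)NC)ccc43)nc2N1c1ccn(C)n1` share one core and differ in a single place: methylcarbamoyl in place of fluoro on an aromatic carbon. In a functional assay on K562 cells (Homo sapiens) for antiproliferative activity, read by CCK-8 assay, with a stated time of 72 h (on this read-out higher numbers stand for weaker inhibition of growth and lower numbers for stronger inhibition of growth), compound 2 gives 6070 nM, and compound 1 gives 13300 nM; the step is a 2.2-fold higher number from compound 2 to compound 1 (0.34 log units; beyond the scatter).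

Compound 3 `CC[C@@H]1C(=O)N(C)c2cnc(-n3ccc4cc(F)ccc43)nc2N1C1CCCC1` carries a second core; the difference between the two cores is not broken down here. In this assay compound 3 gives 21200 nM. Against compound 1 this stands within the scatter; against compound 2 it lies beyond the scatter.

Compound 4 `CC[C@@H]1C(=O)N(C)c2cnc(-n3ccc4cc(C(=O)NC)ccc43)nc2N1C1CCCC1` is not yet measured. It relates to compound 3 as compound 1 relates to compound 2: methylcarbamoyl in place of fluoro on an aromatic carbon. The place is the same word for word in both pairs, so this is the same change, now on the second core.

Expectation. Going by the values given here, only one earlier instance of the change is in hand. In this assay the expected step is a 2.2-fold higher number from compound 3 to compound 4 (0.34 log units; beyond the scatter), resting on a 2.2-fold higher number from compound 2 to compound 1 (0.34 log units; beyond the scatter). The starting level is given by compound 3 at 21200 nM, already the highest number among the three measured compounds. Compound 4 is therefore expected to give about 46000 nM in this assay. The range for compound 4 is estimated from 24000 nM to 90000 nM. At this level the assay may report only a limit rather than a number.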

Compound 4, concentration for 50% growth inhibition: 705 nM
The estimate for compound 4 lay 65-fold (1.81 log units) above the measured number; measured number outside the range, below it.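

On the second core, in this assay, methylcarbamoyl in place of fluoro on an aromatic carbon brings a 30-fold lower number from compound 3 to compound 4 (1.48 log units; beyond the scatter). Set beside the earlier step, the same change runs in the opposite direction, so neither the size nor the direction of a step read on one core carries over to the other in this series: the same change on two cores in this assay, a 2.2-fold higher number (0.34 log units; beyond the scatter) from compound 2 to compound 1 and a 30-fold lower number (1.48 log units; beyond the scatter) from compound 3 to compound 4, 66-fold (1.82 log units) apart, beyond the scatter of two such steps
This shows that the outcome of the change depends on the core for these two pairs, but it does not show which part of the core matters, and two pairs give no general rule for the series.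

The compounds shown leave open how a carboxylic acid, an unsubstituted carboxamide or a longer chain on the amide nitrogen would behave in the same place on either core, and so whether the reversal is particular to methylcarbamoyl. They also leave open which part of the difference between the two cores goes with the reversal, and whether it appears in any read-out other than growth inhibition in these cells.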